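Trimming the Urea Chain of a Sulfonamide Cytotoxin

The source may hold more compounds than are shown below. What is called first, only, known or untested is meant among the compounds shown, and "the series" means these compounds.

Compound 2 `CCCc1ccccc1NS(=O)(=O)c1ccc(NC(=O)NCCCCl)cc1` is one of three close relatives assessed in a functional assay on M21 cells (Homo sapiens) for cytotoxicity, read by sulforhodamine B assay, with a stated time of 48 h; on this read-out lower numbers stand for stronger inhibition and higher numbers for weaker inhibition. Among the two numbers given, compound 2 stands highest with 38000 nM. Among the measured compounds shown here, compound 3 `CCCc1ccccc1OS(=O)(=O)c1ccc(NC(=O)NCC)cc1` gives 800 nM in this assay, but it differs from compound 2 in two places, so no single step links them. Compound 1 `CCc1ccccc1NS(=O)(=O)c1ccc(NC(=O)NCCCCl)cc1` returns only a limit, > 200000 nM. For the measured compounds named here, the one measured step, an at least 5.2-fold lower number from compound 1 to compound 2 (0.72 log units; beyond the scatter), concerns the chain on the aromatic ring and not the urea end. Compound 4 `CCCc1ccccc1NS(=O)(=O)c1ccc(NC(=O)NCC)cc1` differs from compound 2 by hydrogen in place of chloromethyl on a saturated chain carbon, two bonds along the chain from an amide-type nitrogen. Going by the values given here, no measured step covers this change on its own. Compound 3, with 800 nM, carries the same ethyl on the urea, yet a second difference elsewhere in its structure means its value cannot be assigned to the shorter chain alone, so only a cautious expectation is possible. Compound 4 is therefore estimated at 8000 nM, between 1500 nM and 40000 nM, an expected step of a 4.8-fold lower number from compound 2 to compound 4 (0.68 log units; beyond the scatter).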

Compound 4, half-maximal inhibitory concentration: 41000 nM
Beside the measured number, compound 4's estimate is 5.1-fold (0.71 log units) below it; measured number outside the range, above it.
By their numbers in this assay, from the lowest: compound 3; then compounds 2 and 4 (each within the scatter of the next). At a limit, above all of these: compound 1.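

In this assay, the urea end of the molecule gets its first direct test: ethyl in place of 3-chloropropyl gives a 1.1-fold higher number from compound 2 to compound 4 (0.03 log units; within the scatter), so on this core the two chains cannot be told apart. The ethyl on the urea therefore does not by itself bring a compound to the value of compound 3, 800 nM, and the remaining difference between compound 4 and compound 3 lies elsewhere in the structure. Nothing measured here speaks to why the two chains read alike.

Still open, on these data alone, is whether an amine, a carboxylic acid or a longer chain at the urea end would read differently on this core. Also open, as far as these compounds go, is whether the same exchange would read alike on the core of compound 3.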